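Piperazine nitrogen substituent and urotensin-2 receptor binding

The source may hold more compounds than are shown below. What is called first, only, known or untested is meant among the compounds shown, and "the series" means these compounds.

Compound 1: `COc1ccc([C@@H](CCCN(C)S(=O)(=O)c2cccs2)N2Cc3c(cccc3N3CCN(C4CC4)CC3)C2=O)cc1OC` with 59 nM
Compound 2: `CCN1CCN(c2cccc3c2CN([C@H](CCCN(C)S(=O)(=O)c2cccs2)c2ccc(OC)c(OC)c2)C3=O)CC1` with < 5 nM

In an assay on RMS13 cells for displacement of a labelled ligand from Urotensin-2 receptor (Homo sapiens), read by scintillation proximity assay (on this read-out lower numbers stand for stronger inhibition and higher numbers for weaker inhibition), compound 1 gives 59 nM. For compound 2 the value of < 5 nM is a limit of this assay, not a number, so compound 2 stands at the limit of < 5 nM in this assay, at which 1 of the 2 values shown sits. The step from compound 1 to compound 2 was an at least 11-fold lower number from compound 1 to compound 2 (1.07 log units; beyond the scatter), showing that this ring nitrogen substituent matters. Compound 3, `COc1ccc([C@@H](CCCN(C)S(=O)(=O)c2cccs2)N2Cc3c(cccc3N3CCNCC3)C2=O)cc1OC`, differs from compound 2 by hydrogen in place of ethyl on an amine nitrogen in a ring. Since compound 2 sits at a limit, the size of the step cannot be read from the numbers; compound 3 is expected to be an at least 3.0-fold higher number from compound 2 to compound 3 (0.47 log units; beyond the scatter). Compound 3 is therefore estimated at 15 nM, within 3 nM to 80 nM.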

Compound 3, inhibition constant: 49 nM
Compound 3: middle estimate off by 3.3-fold (0.51 log units), on the low side, within the range that was stated.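

Taking the ethyl off this nitrogen gives an at least 9.8-fold higher number from compound 2 to compound 3 (0.99 log units; beyond the scatter) in this assay, so the stronger binding goes with the ethyl group itself and not merely with the loss of cyclopropyl. Hydrogen and cyclopropyl at this position cannot be told apart, with a 1.2-fold lower number from compound 1 to compound 3 (0.08 log units; within the scatter). The value of compound 2 is a limit and not a number, so the full size of its steps stays unread: the limit of < 5 nM in this assay, at which 1 of the 3 values shown sits.

As far as these compounds go, whether a methyl group or a longer chain such as propyl on this nitrogen would match ethyl remains open. From the compounds shown here alone, how far the true value of compound 2 lies past its limit also remains open.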